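Working notes on compound 3 and compound 4

The source may report more compounds than this note shows. Statements on the series, on what has been measured and on what is new or still open speak of the compounds shown alone.

Three compounds carry a result in a functional assay on the whole organism with Rattus norvegicus as the target; a higher number here means that more compound is needed for the effect, a lower number that less compound is needed. Compound 1 `CCCCCCCc1ccc2nc(N)sc2c1` reaches only a limit, > 10 mg/kg, which is a bound of the assay and not a number. Compound 2 `Nc1nc2ccc(C(=O)C(F)(F)F)cc2s1` likewise stops at a limit, > 10 mg/kg. Among the measured compounds shown here, compound 3 `C=CCn1c(=N)sc2cc(OC(F)(F)F)ccc21` is the one member with a measured number, 7 mg/kg, and so stands alone among the values shown: the other two sit at the limit of > 10 mg/kg in this assay, at which 2 of the 3 values shown sit. For the measured compounds named here, no step between two measured compounds that differ in a single place is available, so the series gives no measured step size to lean on.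

Compound 4 `CCCSCCn1c(=N)sc2cc(OC(F)(F)F)ccc21` has not yet been run in this assay. It differs from compound 3 by (propylsulfanyl)methyl in place of vinyl on a saturated chain carbon bound to an aromatic nitrogen, the vinyl group giving way to (propylsulfanyl)methyl on the saturated chain carbon bound to the aromatic nitrogen; cut one bond further out, allyl becomes 2-(propylsulfanyl)ethyl. The shared core of compound 3 is kept. Going by the values given here, with no measured step in hand, the step is expected to be small, a 1.1-fold higher number from compound 3 to compound 4 (0.06 log units; within the scatter), with no direction asserted beyond the scatter, though a drift toward a higher dose cannot be excluded. Compound 4 is accordingly estimated at 8 mg/kg in this assay, with a range from 3 mg/kg to 20 mg/kg.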

Compound 4, dose for half-maximal effect: 2.4 mg/kg
Compound 4: middle estimate off by 3.3-fold (0.52 log units), on the high side; measured number outside the range, below it.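

Among the compounds shown here, this is the first measured step, and it shows that the place on a saturated chain carbon bound to an aromatic nitrogen responds to substitution in this assay: (propylsulfanyl)methyl in place of vinyl gives a 2.9-fold lower number from compound 3 to compound 4 (0.46 log units; beyond the scatter). The longer 2-(propylsulfanyl)ethyl chain is therefore accepted in place of allyl with the shared core unchanged, and less compound is needed for the effect, not more. The change still bundles several differences at once, as a sulfur atom and a hydrogen-bond acceptor enter, the chain grows and the double bond leaves, and compound 1 and compound 2 offer no further step to separate these, since each stops at a limit and not a number: the limit of > 10 mg/kg in this assay, at which 2 of the 4 values shown sit.

Which of those differences goes with the lower number stays open, and a comparison of 2-(propylsulfanyl)ethyl with an all-carbon hexyl chain or with its ether-oxygen counterpart would begin to separate them. Also open, going by these compounds, are how far the chain can grow at this place and whether a terminal amine or carboxylic acid on it would keep the step.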